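A few compounds are considered here, and "the series" means these few. Any claim that something is new, unique, unknown or untested is made for them only; others in the source may bear on it.

Measured compounds, with their readings in a functional assay on OVCAR-8 cells (Homo sapiens) for inhibition, read by sulforhodamine B assay, with a stated time of 48 h; a lower number here means a stronger inhibitor of growth, a higher number a weaker inhibitor of growth:

Compound 1 `Nc1cc(N)c2nc(-c3ccccc3)c(Oc3ccc(Cl)c(Cl)c3)nc2c1` gives 28200 nM.
Compound 2 `COc1cc(CNc2nc3cc(N)cc(N)c3nc2-c2ccccc2)cc(OC)c1OC` gives 6920 nM.
Compound 3 `Nc1cc(N)c2nc(-c3ccccc3)c(Sc3ccc(Cl)c(Cl)c3)nc2c1` gives 24500 nM.

Among these three numbers compound 3 stands second highest. Among the measured compounds shown here, its nearest neighbour is compound 1, whose number is higher but within the usual scatter; the only measured single-point step, a 1.2-fold lower number from compound 1 to compound 3 (0.06 log units; within the scatter), connects these two and is within the scatter as well. The furthest is compound 2, whose lower number lies beyond the scatter and so marks a real difference in this assay.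

The new compound, compound 4 `Nc1cc(N)c2nc(-c3ccccc3)c(Sc3ccc(F)cc3)nc2c1`, differs from compound 3 in one place: 4-fluorophenyl in place of 3,4-dichlorophenyl on a sulfur. For the measured compounds named here, no measured step concerns a change of this kind. Going by the values given here, the one step on record, from compound 1 to compound 3, swaps the linking atom and leaves the 3,4-dichlorophenyl untouched, so it says nothing direct about what happens when that group itself is replaced. Compound 2 carries a different kind of group altogether and offers no single-point comparison.

Among the compounds with values here, with no bearing step available, the expectation for compound 4 is a number close to that of compound 3, with a step of a 1.2-fold higher number from compound 3 to compound 4 (0.09 log units; within the scatter) that is expected to stay within the scatter. Compound 4 is therefore estimated at 30000 nM, with a likely range from 10000 nM to 90000 nM.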

Compound 4, concentration for 50% growth inhibition: 16600 nM
Compound 4: middle estimate off by 1.8-fold (0.26 log units), on the high side; the range from low to high includes it.
By their numbers in this assay, from the lowest: compound 2; then compounds 4, 3 and 1 (each within the scatter of the next).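

Among the compounds shown here, replacing 3,4-dichlorophenyl with 4-fluorophenyl on the sulfur gives a 1.5-fold lower number from compound 3 to compound 4 (0.17 log units; within the scatter) in this assay, the first reading of a change to this ring itself, and the two compounds cannot be told apart in this assay. For the compounds shown here, changing the linking atom and the ring together gives a 1.7-fold lower number from compound 1 to compound 4 (0.23 log units; within the scatter) and also stays inside the usual scatter, so neither the single change nor the double change separates these compounds. No supporting measurement is available to explain why the readings stay so close.

The compounds shown leave open whether a plain phenyl, with neither chlorine nor fluorine, or a ring carrying an amine or a carboxylic acid would give a reading beyond the scatter on this sulfur. They also leave open whether 4-fluorophenyl would read the same when joined through oxygen, which would show whether the linking atom and the ring act independently of each other.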